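The source may report more compounds than this note shows. Statements on the series, on what has been measured and on what is new or still open speak of the compounds shown alone.

Compound 3 `COC(=O)c1cc(O)ccc1OC(=O)COc1cc(O)c2c(=O)cc(-c3ccccc3)oc2c1` is one of three related compounds tested in an ADME assay on cells (T-cell, Mus musculus, strain BALB/c) for cytotoxicity, read by MTT assay, with a stated time of 48 h (on this read-out lower numbers stand for higher toxicity in this test and higher numbers for lower toxicity in this test), where compound 3 gives 263000 nM. Compound 1 `COC(=O)c1c(F)cccc1OC(=O)COc1cc(O)c2c(=O)cc(-c3ccccc3)oc2c1` gives 319000 nM in this assay, and compound 2 `COC(=O)c1c(Cl)cc(Cl)cc1OC(=O)COc1cc(O)c2c(=O)cc(-c3ccccc3)oc2c1` gives 345000 nM; all three numbers sit within the usual scatter of one another. Within the data shown here, the only single-point change among them, a 1.2-fold lower number from compound 1 to compound 3 (0.08 log units; within the scatter), concerns the same place that is altered next. Compound 4 `COC(=O)c1c(C)cccc1OC(=O)COc1cc(O)c2c(=O)cc(-c3ccccc3)oc2c1` carries a group of 11 heavy atoms (9 carbon, 2 oxygen; one six-membered aromatic ring of carbon only) in place of a group of 11 heavy atoms (8 carbon, 3 oxygen; one six-membered aromatic ring of carbon only), on an oxygen next to a carbonyl group. Because that earlier exchange on an oxygen next to a carbonyl group gave a 1.2-fold lower number from compound 1 to compound 3 (0.08 log units; within the scatter), and compounds 2 and 3 also sit close together, the account expects no step beyond the scatter in this assay for the move a 1.1-fold higher number from compound 3 to compound 4 (0.06 log units; within the scatter). Compound 4 is therefore estimated at 300000 nM, within 150000 nM to 600000 nM.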

Compound 4, half-maximal cytotoxic concentration: 298000 nM
The estimate for compound 4 lay 1.0-fold (0.00 log units) above the measured number; measured number inside the range.
By their numbers in this assay, from the lowest: compounds 3, 4, 1 and 2 (each within the scatter of the next).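

In this assay, this position now takes a group with 0 hydrogen-bond donors in place of one with 1 hydrogen-bond donor, with a 1.1-fold higher number from compound 3 to compound 4 (0.05 log units; within the scatter) as the result. Methyl in place of fluoro on an aromatic carbon gives a 1.1-fold lower number from compound 1 to compound 4 (0.03 log units; within the scatter), so this exchange also stays within the scatter. No evidence is at hand to explain these results.

The compounds shown leave open whether an amine or a carboxylic acid on this aromatic ring would give a step beyond the scatter. They also leave open whether any change elsewhere in the shared core would do so.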